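Carboxy to Carbamoyl on Compound 3

A few compounds are considered here, and "the series" means these few. Any claim that something is new, unique, unknown or untested is made for them only; others in the source may bear on it.

In a functional assay on A549 cells (Homo sapiens) for cytotoxicity, read by MTT assay, with a stated time of 72 h (a lower number here means a stronger inhibitor, a higher number a weaker inhibitor), compound 3 `Cc1csc(-c2ccnc(Nc3ccc(C(=O)O)cc3)n2)c1` gives 18200 nM and compound 1 `COc1ccc(-c2ccnc(Nc3ccc(C(=O)O)cc3)n2)cc1` gives 20300 nM, so the two sit within the scatter of each other. Compound 2 `COc1ccc(-c2ccnc(Nc3ccc(C(N)=O)cc3)n2)cc1` gives 5300 nM, the lowest number of the three. Compound 4 `Cc1csc(-c2ccnc(Nc3ccc(C(N)=O)cc3)n2)c1` differs from compound 3 by amino in place of hydroxy on a carbonyl carbon, that is, carboxy to carbamoyl (amino in place of hydroxy on a carbonyl carbon). The same change produced a 3.8-fold lower number from compound 1 to compound 2 (0.58 log units; beyond the scatter), a modest step. The other measured change, 4-methylthiophen-2-yl in place of 4-methoxyphenyl, produced a 1.1-fold lower number from compound 1 to compound 3 (0.05 log units; within the scatter), so the earlier step seems a fair guide here. A similar fall in this assay is therefore expected, an estimated 3.8-fold lower number from compound 3 to compound 4 (0.58 log units; beyond the scatter). For compound 4 the expected value is 4800 nM, with an estimated range of 2200 nM to 10500 nM.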

Compound 4, half-maximal inhibitory concentration: 30000 nM
Compound 4: middle estimate off by 6.3-fold (0.80 log units), on the low side, and the stated range ends below it.
By their numbers in this assay, from the lowest: compound 2; then compounds 3, 1 and 4 (each within the scatter of the next).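

In this assay, the carboxy to carbamoyl change does not carry over to the core of compound 3, giving a 1.6-fold higher number from compound 3 to compound 4 (0.22 log units; within the scatter). The swap of 4-methoxyphenyl for 4-methylthiophen-2-yl, which made no clear difference with carboxy present, gives a 5.7-fold higher number from compound 2 to compound 4 (0.75 log units; beyond the scatter) with carbamoyl present. The two changes therefore do not simply add, and the size of each depends on the group present at the other place: the same change on two cores in this assay, a 3.8-fold lower number (0.58 log units; beyond the scatter) from compound 1 to compound 2 and a 1.6-fold higher number (0.22 log units; within the scatter) from compound 3 to compound 4, 6.3-fold (0.80 log units) apart, beyond the scatter of two such steps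

The compounds shown leave open whether a methyl ester or a nitrile in place of carbamoyl would behave as it does with 4-methoxyphenyl or with 4-methylthiophen-2-yl.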